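The source may report more compounds than this note shows. Statements on the series, on what has been measured and on what is new or still open speak of the compounds shown alone.

Of the compounds shown here, two built on a shared core have been measured in an in vitro ADME assay on microsomes from liver (Mus musculus) for metabolic stability; on this read-out lower numbers stand for a shorter-lived compound and higher numbers for a longer-lived compound. Compound 1 `Cn1cncc1CN1C(=O)C(N(CC(=O)NC(C)(C)C)S(=O)(=O)c2cccc(F)c2)Cc2cc(C#N)ccc21` gives 31 h in this assay. Compound 2 `Cn1cnc(S(=O)(=O)N(Cc2ccc(-n3cccn3)cc2)C2Cc3cc(C#N)ccc3N(Cc3cncn3C)C2=O)c1` gives 9 h, the lower of the two numbers; its distance from compound 1 lies beyond the usual scatter of repeated measurements, so compound 2 is the shorter-lived of the pair. Among the measured compounds shown here, no single-change step between these two exists, as they differ in more than one place, so their values can only be set side by side.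

Compound 3 `Cn1cnc(S(=O)(=O)N(CC(=O)OC(C)(C)C)C2Cc3cc(C#N)ccc3N(Cc3cncn3C)C2=O)c1` has not yet been measured. It differs from compound 2 in one place: tert-butoxycarbonyl in place of 4-(1H-pyrazol-1-yl)phenyl on a saturated chain carbon bound to a sulfonamide nitrogen. The incoming group loosely resembles a piece of compound 1, which holds the longer value 31 h, but compound 1 differs from compound 3 elsewhere too, so this is a pointer rather than a rule. On that pointer, a modest lengthening is expected, a 1.7-fold higher number from compound 2 to compound 3 (0.22 log units; within the scatter), though a result within the scatter would not surprise. Compound 3 is estimated at 15 h in this assay, within a range from 5 h to 40 h.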

Compound 3, half-life: 21 h
The estimate for compound 3 lay 1.4-fold (0.15 log units) below the measured number; measured number inside the range.
By their numbers in this assay, from the lowest: compound 2; then compounds 3 and 1 (each within the scatter of the next).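

Among the compounds shown here, the first single change in this set falls on a saturated chain carbon bound to a sulfonamide nitrogen: in this assay, tert-butoxycarbonyl in place of 4-(1H-pyrazol-1-yl)phenyl gives a 2.3-fold higher number from compound 2 to compound 3 (0.37 log units; beyond the scatter), so the read-out does respond to what sits at this position. The exchange removes both aromatic rings and lowers the heavy-atom count, while the count of hydrogen-bond acceptors stays the same and neither group has a donor; because these differences arrive together, this one step cannot separate them. Nothing measured here accounts for the size or direction of this step.

As far as these compounds go, it remains open whether the longer half-life goes with losing the rings or with gaining the tert-butoxycarbonyl group, and a plain phenyl group or a carboxylic acid at the same place would help tell these apart. Also open, from the compounds shown here alone, is how a tert-butyl amide would behave at this place with the rest of compound 3 held constant, since that would test the ester against a closely matched group in a single change.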